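The compounds below may be only part of what the source reports. "The series", "measured", "known", "first", "only" and "open" are said of these compounds alone.

Working notes on the series.

Of the compounds shown here, three of the shared core have been measured in a functional assay on A549 cells (Homo sapiens) for antiproliferative activity, read by MTT assay, with a stated time of 72 h; a higher number here means a weaker inhibitor, a lower number a stronger inhibitor. Compound 1, `COc1cc(-n2cnc3ccc(-c4ccc(C(F)(F)F)cc4)cc32)cc(OC)c1OC`, gives 3390 nM in this assay. Compound 2, `COc1cc(-n2cnc3ccc(-c4ccc(Cl)cc4)cc32)cc(OC)c1OC`, reaches only the limit of this assay, > 10000 nM. Compound 3, `COc1ccc(-c2ccc3ncn(-c4cc(OC)c(OC)c(OC)c4)c3c2)cc1`, likewise reaches only the limit of this assay, > 10000 nM. Two of the three values shown thus sit at the limit of > 10000 nM in this assay, at which 2 of the 3 values shown sit. The step of an at least 2.9-fold higher number from compound 1 to compound 2 (0.46 log units; beyond the scatter) and the step of an at least 2.9-fold higher number from compound 1 to compound 3 (0.46 log units; beyond the scatter) both point the same way; the step that the two limits leave unreadable from compound 2 to compound 3 cannot be read because both values sit at the limit of > 10000 nM in this assay, at which 2 of the 3 values shown sit.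

For the measured compounds named here, compound 3 therefore stands at the limit, with compound 1 the only numbered value in this assay. The next compound, compound 4, `COc1cc(-n2cnc3ccc(-c4cccc(O)c4)cc32)cc(OC)c1OC`, differs from compound 3 by 3-hydroxyphenyl in place of 4-methoxyphenyl on an aromatic carbon. Going by the values given here, no measured step bears directly on this change; the two readable steps, from compound 1 to compound 2 and from compound 1 to compound 3, show only that exchanges on this ring move the number by at least a modest amount, and a limit is the starting point here. The step of an at least 1.1-fold lower number from compound 3 to compound 4 (0.04 log units; that floor lies within the scatter) is therefore expected to be small and uncertain in direction. For compound 4 the estimate in this assay is 9000 nM, within a range from 2500 nM to 30000 nM.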

Compound 4, half-maximal inhibitory concentration: 250 nM
The estimate for compound 4 lay 36-fold (1.56 log units) above the measured number; measured number below the stated range.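

Exchanges at this position can do far more than the earlier compounds showed, where the one readable contrast was a modest one among the 4-substituted phenyl groups: in this assay, 3-hydroxyphenyl in place of 4-methoxyphenyl gives an at least 40-fold lower number from compound 3 to compound 4 (1.60 log units; beyond the scatter), and 3-hydroxyphenyl in place of 4-chlorophenyl gives an at least 40-fold lower number from compound 2 to compound 4 (1.60 log units; beyond the scatter). For the compounds shown here, the gain does not rest on limits alone, since 3-hydroxyphenyl in place of 4-(trifluoromethyl)phenyl, the only earlier comparison with a true number, gives a 14-fold lower number from compound 1 to compound 4 (1.13 log units; beyond the scatter). The first two steps are floors, and their full size cannot be read: the limit of > 10000 nM in this assay, at which 2 of the 4 values shown sit.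

The change alters the substituent and where it sits on the phenyl ring at once, so the compounds shown do not separate the effect of the hydroxyl group from that of its placement; 4-hydroxyphenyl and 3-methoxyphenyl at this position would pull the two apart. Whether the hydroxyl itself is needed also stays open, as the compounds shown do not say how an amine or a carboxylic acid at the same place on the ring would read.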